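Double-bond geometry in the sulfonyl compound: E versus Z

The compounds below may be only part of what the source reports. "The series", "measured", "known", "first", "only" and "open" are said of these compounds alone.

Measured so far in a functional assay on HeLa cells (Homo sapiens) for inhibition; on this read-out higher numbers stand for weaker inhibition and lower numbers for stronger inhibition 
- compound 1 `COc1cc(/C=C/c2ccc(N(C)C)c([N+](=O)[O-])c2)cc(OC)c1OC` gives > 5000 nM (a limit)
- compound 2 `COc1cc(/C=C/c2ccc3c(ccn3S(=O)(=O)c3ccccc3)c2)cc(OC)c1OC` gives > 5000 nM (a limit)

In this assay compound 2 reads > 5000 nM and this is a limit of the assay, not a number. Within the data shown here, the whole data set consists of such readings, as the limit of > 5000 nM in this assay, at which 2 of the 2 values shown sit, shows, so no measured step is available to size the next one.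

Compound 3 `COc1cc(/C=C\c2ccc3c(ccn3S(=O)(=O)c3ccccc3)c2)cc(OC)c1OC` is the untested partner of compound 2. The change is the two compounds have the same atoms and bonds and differ only in configuration as drawn: 1 of 1 stereo elements differ; a double bond is drawn E in compound 2 and Z in compound 3 and nothing else: a double bond is drawn E in compound 2 and Z in compound 3.

Among the measured compounds shown here, with no measured step to lean on, the expectation rests on this change alone and is loose. A shift toward stronger inhibition, beyond the usual scatter, is expected, although another limit reading remains a real possibility. The expected size is an at least 12-fold lower number from compound 2 to compound 3 (1.09 log units; beyond the scatter), an estimate that is itself bounded only by the limit on compound 2. For compound 3 the estimated value is 400 nM, with an expected range from 20 nM to 5000 nM in this assay.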

Compound 3, half-maximal inhibitory concentration: > 5000 nM
Compound 3: only a limit was reported (the forecaster's own chance of this, stated with the estimate: 30%); middle value at least 12-fold (1.09 log units) away from the limit.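

No step can be read from compound 2 to compound 3 in this assay, since both readings are limits and not numbers: the limit of > 5000 nM in this assay, at which 3 of the 3 values shown sit. The compounds shown leave open whether the change from the E to the Z double bond shifts inhibition at all, and in which direction.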